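A Hydroxyl Enters the Sulfonate Aryl Ring

A few compounds are considered here, and "the series" means these few. Any claim that something is new, unique, unknown or untested is made for them only; others in the source may bear on it.

Compound 1 `O=C(c1ccccc1)c1ccc(OS(=O)(=O)c2ccc(Cl)cc2Cl)cc1` gives 0% in an assay on CHO cells for binding affinity to integrin alpha-1 (Homo sapiens), read by WST assay, with a stated time of 2 h, tested at 50 uM (a lower number here means less inhibition, a higher number more inhibition at the concentration tested (going by the name of the read-out)), the lowest of the two numbers measured here. Among the measured compounds shown here, compound 2 `O=C(c1ccccc1)c1ccc(NS(=O)(=O)c2ccc(I)cc2)cc1` gives 85% in this assay, a gap that lies beyond the usual scatter; no single step joins these two compounds. Compound 3 `O=C(c1ccccc1)c1ccc(OS(=O)(=O)c2cc(Cl)cc(Cl)c2O)cc1` differs from compound 1 by one change: 3,5-dichloro-2-hydroxyphenyl in place of 2,4-dichlorophenyl on a sulfonyl sulfur. Nothing measured here shows what a hydroxyl on this ring does, so the outcome is uncertain. The step of a number 15 percentage points higher from compound 1 to compound 3 (beyond the scatter) is expected to be small and upward, hardly beyond the scatter. Compound 3 is therefore expected to give 15% in this assay, within a range from 0% to 55%.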

Compound 3, a percentage reported as inhibition, at one concentration (the size of the read-out at that concentration, not a potency): 86%
Estimate against measurement, compound 3: 71 percentage points below; the whole stated range lies below it.
By their numbers in this assay, from the lowest: compound 1; then compounds 2 and 3 (each within the scatter of the next).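

In this assay, putting 3,5-dichloro-2-hydroxyphenyl in place of 2,4-dichlorophenyl on a sulfonyl sulfur gives a number 86 percentage points higher from compound 1 to compound 3 (beyond the scatter). The sulfonate link of compound 1 therefore does not by itself rule out inhibition at the concentration tested, and the group on the sulfur makes a large difference here. Nothing available explains this step.

As far as these compounds go, the change adds a hydroxyl and also alters the chlorine pattern, so the share of each remains open. From the compounds shown here alone, whether a methoxy group in place of that hydroxyl would keep the step also remains open.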